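From pyridin-3-yl to pyrimidin-2-yl on compound 1

This account rests on a few compounds, and the source may have more. Where it says the series, first, only, none or still open, it means among the compounds named here.

Measured in a functional assay on L5178Y cells (Mus musculus) for antiproliferative activity, read by MTT assay; on this read-out lower numbers stand for stronger inhibition and higher numbers for weaker inhibition:
Compound 1 `CC(=O)c1ccc(OCCCCN2CCN(c3cccnc3)CC2)cc1`: 24.2 nM
Compound 2 `CCC(C)(C)c1ccc(OCCCCN2CCN(c3cccnc3)CC2)cc1`: 3.23 nM

Compound 1 holds the higher number of the two and is thus the weaker inhibitor of the pair. The gap between them is a 7.5-fold lower number from compound 1 to compound 2 (0.87 log units; beyond the scatter). Compound 3 `CC(=O)c1ccc(OCCCCN2CCN(c3ncccn3)CC2)cc1` differs from compound 1 in one place, with pyrimidin-2-yl in place of pyridin-3-yl on an amine nitrogen in a ring. Among the compounds with values here, the only measured step involves a different change, 1,1-dimethylpropyl in place of acetyl on an aromatic carbon, and no measured pair covers the new swap. That step therefore sets neither a size nor a direction for it. In this assay, no step beyond the scatter is expected, so the expectation stays anchored on compound 1 at 24.2 nM. The expected change is a 1.2-fold higher number from compound 1 to compound 3 (0.06 log units; within the scatter). Compound 3 is estimated at 28 nM, with an expected range from 7 nM to 110 nM.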

Compound 3, half-maximal inhibitory concentration: 31.6 nM
For compound 3 the middle estimate is 1.1-fold (0.05 log units) below the measured one; the measured number falls inside the stated range.
By their numbers in this assay, from the lowest: compound 2; then compounds 1 and 3 (each within the scatter of the next).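

In this assay, within the data shown here, pyrimidin-2-yl in place of pyridin-3-yl on the amine nitrogen in a ring gives a 1.3-fold higher number from compound 1 to compound 3 (0.12 log units; within the scatter), the first measured step at this position. Going from one hetero atom to two in this six-membered aromatic ring, with the heavy-atom count unchanged, therefore does not separate the two compounds on this read-out. Nothing measured here bears on why they read alike.

The compounds shown leave open whether pyrimidin-2-yl would read the same alongside 1,1-dimethylpropyl, since compound 2 carries pyridin-3-yl and the step is known only with acetyl on the aromatic carbon. They also leave open whether a phenyl ring, with no ring nitrogen at all, or a 2-methoxyphenyl group on that amine nitrogen would stay within the scatter of compound 1.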